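The source may report more compounds than this note shows. Statements on the series, on what has been measured and on what is new or still open speak of the compounds shown alone.

Measured so far:
compound 1 `O=C(Nc1cnc2[nH]ncc2c1)[C@H]1CCCN1C(=O)C1(c2cccc(Cl)c2)CCCC1` — 15.9 nM
compound 2 `O=C1Cc2cc(NC(=O)[C@H]3CCCN3C(=O)C3(c4cccc(Cl)c4)CCCC3)ccc2N1` — 0.794 nM
compound 3 `O=C(Nc1ccc2[nH]nnc2c1)[C@H]1CCCN1C(=O)C1(c2cccc(Cl)c2)CCCC1` — 20 nM

In an assay on isolated protein for inhibition of histone acetyltransferase p300 (Homo sapiens), with a stated time of 60 min (a higher number here means a weaker inhibitor, a lower number a stronger inhibitor), compound 3 gives the highest of the three numbers; it sits next to compound 1, with a 1.3-fold higher number from compound 1 to compound 3 (0.10 log units; within the scatter), and far from compound 2, with a 25-fold higher number from compound 2 to compound 3 (1.40 log units; beyond the scatter). Compound 4 `CNC(=O)c1cccc(NC(=O)[C@H]2CCCN2C(=O)C2(c3cccc(Cl)c3)CCCC2)c1` differs from compound 3 by a group of 10 heavy atoms (8 carbon, 1 nitrogen, 1 oxygen; one six-membered aromatic ring of carbon only) in place of a group of 9 heavy atoms (6 carbon, 3 nitrogen; one five-membered aromatic ring with 3 hetero atoms, one six-membered aromatic ring of carbon only), on an amide-type nitrogen. For the measured compounds named here, no measured step replaces a bicyclic aromatic group with a single benzene ring, so the steps bear only indirectly: compound 2, which carries a non-aromatic ring with a hydrogen-bond donor, shows a large gain through a 25-fold higher number from compound 2 to compound 3 (1.40 log units; beyond the scatter), while the two aromatic bicycles of compound 1 and compound 3 lie close. Compound 4 is therefore expected to give a modest step downward, a 2.5-fold lower number from compound 3 to compound 4 (0.40 log units; beyond the scatter), and an estimated 8 nM (range 2 nM to 40 nM).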

Compound 4, half-maximal inhibitory concentration: 1260 nM
Estimate against measurement, compound 4: 160-fold (2.20 log units) below; the whole stated range lies below it.
By their numbers in this assay, from the lowest: compound 2; then compounds 1 and 3 (each within the scatter of the next); then compound 4.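

On the amide-type nitrogen, the 3-(methylcarbamoyl)phenyl group brings a large loss in this assay against all three earlier groups: a 63-fold higher number from compound 3 to compound 4 (1.80 log units; beyond the scatter), a 79-fold higher number from compound 1 to compound 4 (1.90 log units; beyond the scatter) and a 1600-fold higher number from compound 2 to compound 4 (3.20 log units; beyond the scatter). Of the four compounds, only compound 4 has no five-membered ring in this group, and it gives the highest number. Nothing available accounts for this loss.

Left open is whether the loss follows from the missing five-membered ring or from the methylcarbamoyl group itself. An unsubstituted phenyl group, or a carboxylic acid or an amine in place of the methylcarbamoyl group, would help separate the two.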